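A 3-Methoxyphenyl in Place of 4-Bromophenyl

The source may hold more compounds than are shown below. What is called first, only, known or untested is meant among the compounds shown, and "the series" means these compounds.

In a functional assay on OCI-My4 cells (Homo sapiens) for antiproliferative activity, read by MTT assay, with a stated time of 72 h (a lower number here means a stronger inhibitor, a higher number a weaker inhibitor), compound 1 (`C[C@H](NC(=O)/C(C#N)=C/c1cccc(Br)n1)c1ccc(Br)cc1`) gives 2000 nM and compound 3 (`CC[C@H](NC(=O)/C(C#N)=C/c1cccc(Br)n1)c1ccccc1`) gives 1700 nM as its own reading, and these two numbers lie within the scatter of each other. For the measured compounds named here, compound 1 therefore stands level with the only other number available. For compound 2 (`N#C/C(=C\c1cccc(Br)n1)C(=O)N[C@@H]1CCCc2ccccc21`) the entry reads "not determined" (no result reported) and adds nothing to the comparison.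

Compound 4 (`COc1cccc([C@H](C)NC(=O)/C(C#N)=C/c2cccc(Br)n2)c1`) departs from compound 1 by 3-methoxyphenyl in place of 4-bromophenyl on a saturated chain carbon bound to an amide-type nitrogen and a saturated chain carbon and so carries 3-methoxyphenyl in place of 4-bromophenyl on a saturated chain carbon bound to an amide-type nitrogen and a saturated chain carbon. Going by the values given here, no measured pair isolates this kind of change, so the data offer no direct guide to its size or direction. The expectation in this assay is therefore for no change beyond the scatter, with the estimated step of a 1.1-fold higher number from compound 1 to compound 4 (0.04 log units; within the scatter) as the working figure. The estimate for compound 4 is 2200 nM with an expected range from 900 nM to 5500 nM until the measurement is in.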

Compound 4, half-maximal inhibitory concentration: 3100 nM
The estimate for compound 4 lay 1.4-fold (0.15 log units) below the measured number; the range from low to high includes it.
By their numbers in this assay, from the lowest: compounds 3, 1 and 4 (each within the scatter of the next).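

In this assay, the first step measured at this position reads a 1.6-fold higher number from compound 1 to compound 4 (0.19 log units; within the scatter), so compound 1 and compound 4 stand level. On a saturated chain carbon bound to an amide-type nitrogen and a saturated chain carbon, 3-methoxyphenyl therefore serves in place of 4-bromophenyl with no change that can be told from the scatter, even though the entering group carries one hydrogen-bond acceptor and the leaving group none. The data at hand offer no measurement that explains this result.

This single step swaps the substituent and its ring position together, so the effects of each cannot be separated; 3-bromophenyl or 4-methoxyphenyl would be needed to tell them apart. Going by these compounds, it also remains open whether this position would accept a ring carrying an amine or a carboxylic acid, or a cyclohexyl ring.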